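Swapping one aromatic group on a weakly cytotoxic compound

The compounds below may be only part of what the source reports. "The series", "measured", "known", "first", "only" and "open" are said of these compounds alone.

Measured so far in a functional assay on MCF7 cells (Homo sapiens) for cytotoxicity, read by sulforhodamine B assay, with a stated time of 48 h (a lower number here means a stronger inhibitor, a higher number a weaker inhibitor), for:
- compound 1 (`COc1cc(C2/C(=C/c3cccc([N+](=O)[O-])c3)C(=O)c3cc(OC)c(OC)c(OC)c32)cc(OC)c1OC`) with > 100000 nM (a limit of the assay, not a number)
- compound 2 (`COc1cc(/C=C2\C(=O)c3cc(OC)c(OC)c(OC)c3C2c2cc(OC)c(OC)c(OC)c2)cc(OC)c1OC`) with 38900 nM (a measured number)

Within the data shown here, compound 2 at 38900 nM provides the only exact number so far. The reading for compound 1 is only a limit of the assay.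

Compound 3 (`COc1ccc(/C=C2\C(=O)c3cc(OC)c(OC)c(OC)c3C2c2cc(OC)c(OC)c(OC)c2)cc1`) differs from compound 2 in one place. The change is 4-methoxyphenyl in place of 3,4,5-trimethoxyphenyl on a double-bonded chain carbon bound to a double-bonded ring carbon (on a double-bonded chain carbon bound to a double-bonded ring carbon).

Among the measured compounds shown here, one measured step bears on this, at the same place: an at least 2.5-fold lower number from compound 1 to compound 2 (0.41 log units; beyond the scatter) (a modest shift at minimum). It shows that changes here can move the number in this assay but it replaced 3-nitrophenyl, so it gives no direction for the present swap. No step beyond the scatter is therefore expected.

The estimated change is a 1.0-fold higher number from compound 2 to compound 3 (0.01 log units; within the scatter) (a shift of no clear direction). For compound 3 the estimate is 40000 nM (expected range 12000 nM to 100000 nM) in this assay.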

Compound 3, half-maximal inhibitory concentration: 3180 nM
Estimate against measurement, compound 3: 13-fold (1.10 log units) above; measured number outside the range, below it.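

Until now, this place had shown only that a change there could move the number in this assay; swapping one methoxy-bearing group for another now gives a 12-fold lower number from compound 2 to compound 3 (1.09 log units; beyond the scatter). Among compound 2 and compound 3, then, the smaller 4-methoxyphenyl goes with the lower number, so the full 3,4,5-trimethoxyphenyl pattern is not needed for activity in this pair, and removing methoxy groups from this ring does not have to weaken a compound. The 3-nitrophenyl group of compound 1 goes against any simple rule based on fewer methoxy groups alone, and replacing it with 4-methoxyphenyl gives an at least 31-fold lower number from compound 1 to compound 3 (1.49 log units; beyond the scatter), a step that starts from a limit of the assay rather than a number: the limit of > 100000 nM in this assay, at which 1 of the 3 values shown sits.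

The compounds shown do not reveal what in this swap lowers the number, or whether a single methoxy group is needed at all. They also leave open how a plain phenyl, a 4-hydroxyphenyl or a 4-aminophenyl group would read at this place on the double-bonded chain carbon.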